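Dropping the ring from a weak growth inhibitor

The source may hold more compounds than are shown below. What is called first, only, known or untested is meant among the compounds shown, and "the series" means these compounds.

Measured in a functional assay on PC-3 cells (Homo sapiens) for antiproliferative activity, read by sulforhodamine B assay; a lower number here means a stronger inhibitor of growth, a higher number a weaker inhibitor of growth:
Compound 1 `CC(C)CCCOc1cccc(O)c1C(=O)/C=C/c1ccc(O)cc1`: 3600 nM
Compound 2 `O=C(/C=C/c1ccc(O)cc1)c1c(O)cccc1OCC1CCCCC1`: > 30000 nM (a limit of the assay)

Compound 2 has no exact number in this assay and stands only at a limit: the limit of > 30000 nM in this assay, at which 1 of the 2 values shown sits. Compound 3 `CC(C)COc1cccc(O)c1C(=O)/C=C/c1ccc(O)cc1` differs from it by isopropyl in place of cyclohexyl on a saturated chain carbon bound to an oxygen on an aromatic ring, with isopropyl in place of cyclohexyl on a saturated chain carbon bound to an oxygen on an aromatic ring. Within the data shown here, one measured step bears on this change: an at least 8.3-fold higher number from compound 1 to compound 2 (0.92 log units; beyond the scatter), with cyclohexyl in place of isopentyl at that same place. As far as these compounds go, compound 3 lacks the ring, as does compound 1 at 3600 nM, so a change of similar size in the opposite direction is expected, though isopropyl itself is untested. The expected change is an at least 5.0-fold lower number from compound 2 to compound 3 (0.69 log units; beyond the scatter). For compound 3 the estimate is 6000 nM, with an expected range of 1500 nM to 25000 nM.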

Compound 3, concentration for 50% growth inhibition: 2970 nM
For compound 3 the middle estimate is 2.0-fold (0.31 log units) above the measured one; low and high end bracket the measured number.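

In this assay, replacing the cyclohexyl with an open chain at this place gives an at least 10-fold lower number from compound 2 to compound 3 (1.00 log units; beyond the scatter) and brings growth inhibition back into a measurable range. Compound 2 stands only at a limit, so this step gives only a lower bound on the size of the change: the limit of > 30000 nM in this assay, at which 1 of the 3 values shown sits. Among these compounds, the two open-chain groups, by contrast, show a 1.2-fold lower number from compound 1 to compound 3 (0.08 log units; within the scatter) and so cannot be told apart in this assay, which leaves cyclohexyl as the only group of the three that stands apart.

As far as these compounds go, these three compounds cannot show whether the loss follows from any ring at this place or from cyclohexyl alone, so the effect of cyclopropyl or phenyl remains open. Also open, from the compounds shown here alone, is how a longer chain, or an amine or a carboxylic acid on the chain, would read in this assay.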